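Notes on the thiophen-3-yl to 1H-pyrazol-1-yl step

The source may hold more compounds than are shown below. What is called first, only, known or untested is meant among the compounds shown, and "the series" means these compounds.

Measured in a functional assay on MCF7 cells (Homo sapiens) for inhibition, with a stated time of 72 h (a higher number here means a weaker inhibitor, a lower number a stronger inhibitor), so far
- compound 1 `NC1CCC(Nc2nc(NCc3ccc(Br)cc3)c3ncn(C4CCCC4)c3n2)CC1` gives 850 nM
- compound 2 `NC1CCC(Nc2nc(NCc3ccc(-c4cccc(F)c4)cc3)c3ncn(C4CCCC4)c3n2)CC1` gives 293 nM
- compound 3 `NC1CCC(Nc2nc(NCc3ccc(-c4ccsc4)cc3)c3ncn(C4CCCC4)c3n2)CC1` gives 145 nM

Compound 3 stands lowest of the three, beyond the scatter of both others. Compound 4 `NC1CCC(Nc2nc(NCc3ccc(-n4cccn4)cc3)c3ncn(C4CCCC4)c3n2)CC1` carries 1H-pyrazol-1-yl in place of thiophen-3-yl on an aromatic carbon, para to a large group (1H-pyrazol-1-yl in place of thiophen-3-yl on an aromatic carbon). Three modest measured steps bear on it: a 2.9-fold lower number from compound 1 to compound 2 (0.46 log units; beyond the scatter) and a 5.9-fold lower number from compound 1 to compound 3 (0.77 log units; beyond the scatter) and, closest to this change, a 2.0-fold lower number from compound 2 to compound 3 (0.31 log units; beyond the scatter) (only just beyond the scatter). Going by the values given here, no measured compound carries 1H-pyrazol-1-yl, so the direction is uncertain. With compound 3 at 145 nM as the lowest of the three, a modest step towards a higher number is expected in this assay for the new group. Compound 4 is estimated at 240 nM (expected range 100 nM to 600 nM). The expected step is a 1.7-fold higher number from compound 3 to compound 4 (0.22 log units; within the scatter) (an estimate).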

Compound 4, half-maximal inhibitory concentration: 139 nM
For compound 4 the middle estimate is 1.7-fold (0.24 log units) above the measured one, and the stated range covers the measured number.
By their numbers in this assay, from the lowest: compounds 4 and 3 (each within the scatter of the next); then compound 2; then compound 1.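

In this assay, a five-membered aromatic ring with 2 hetero atoms serves at this position as well as thiophen-3-yl, with a 1.0-fold lower number from compound 3 to compound 4 (0.02 log units; within the scatter), so sulfur is not needed here. The 1H-pyrazol-1-yl group also keeps the advantage over the earlier groups, with a 2.1-fold lower number from compound 2 to compound 4 (0.32 log units; beyond the scatter) and a 6.1-fold lower number from compound 1 to compound 4 (0.79 log units; beyond the scatter). Nothing available explains why the two rings read alike.

Still open, going by these compounds, is whether a morpholine or a carboxylic acid on the same aromatic carbon would hold the level of compound 3 and compound 4.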